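The source may report more compounds than this note shows. Statements on the series, on what has been measured and on what is new or still open speak of the compounds shown alone.

Compound 1 `O=S1(=O)C=C(OCc2ccccc2)C(Cc2ccccc2)(Cc2ccccc2)O1`: 200000 nM
Compound 2 `CC1(Cc2ccccc2)OS(=O)(=O)C=C1OCc1ccccc1`: > 400000 nM
Compound 3 `CCC1(Cc2ccccc2)OS(=O)(=O)C=C1OCc1ccc(Cl)cc1`: >= 50000 nM

All three were tested in an ADME assay on HEL cells (Homo sapiens) for cytotoxicity, with a stated time of 3 days; on this read-out lower numbers stand for higher toxicity in this test and higher numbers for lower toxicity in this test. Compound 1 gives 200000 nM. For compound 2 the result is a limit of the assay, > 400000 nM. For compound 3 the result is likewise only a limit, >= 50000 nM, so its place among the three can be given as a floor and not as a number. Among the compounds with values here, the single step between measured compounds that differ in one place, an at least 2.0-fold higher number from compound 1 to compound 2 (0.30 log units; that floor lies within the scatter), runs from a value up to a limit and concerns hydrogen in place of phenyl on a saturated chain carbon bound to a saturated ring carbon.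

Compound 4 `CCC1(Cc2ccccc2)OS(=O)(=O)C=C1OCc1ccc(F)cc1` differs from compound 3 by fluoro in place of chloro on an aromatic carbon. Within the data shown here, no measured step concerns fluoro in place of chloro on an aromatic carbon, so nothing among the measured compounds sets a size or a direction for this change. The expected step, a step that the limit leaves unreadable from compound 3 to compound 4, therefore lies within the scatter. The estimate for compound 4 is 100000 nM, with a range from 50000 nM to 400000 nM.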

Compound 4, minimum cytotoxic concentration: >= 50000 nM
Compound 4 gave a limit, no number (the forecaster's own chance of this, stated with the estimate: 60%); the middle value does not contradict the limit.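

Compound 3 and compound 4 both give only a limit in this assay, so no step can be read between them: the limit of >= 50000 nM in this assay, at which 2 of the 4 values shown sit.

The compounds shown leave open whether fluoro in place of chloro on an aromatic carbon changes the result in this test at all, and in which direction.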